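Chlorinated carboxyphenyl ether on the cyclopentyl core

The source may report more compounds than this note shows. Statements on the series, on what has been measured and on what is new or still open speak of the compounds shown alone.

Compound 1 `Cc1c(OCCCCOc2cccc(C(=O)O)c2)ccc(C(=O)CC(C)C)c1C` gives 18.3% in an assay on HEK293 cells for positive allosteric modulation of metabotropic glutamate receptor 3 (Rattus norvegicus), read by thallium flux, with a stated time of 2.5 min; a lower number here means a smaller maximal response, a higher number a larger maximal response. Compound 2 `Cc1c(OCCCCOc2ccc(C(=O)O)c(Cl)c2)ccc(C(=O)CC(C)C)c1C` carries 4-carboxy-3-chlorophenyl in place of 3-carboxyphenyl on an oxygen on a saturated carbon and gives 12% in this assay; the step is a number 6.3 percentage points lower from compound 1 to compound 2 (within the scatter). Compound 3 `Cc1c(OCCCCOc2cccc(C(=O)O)c2)ccc(C(=O)CC2CCCC2)c1C` gives 16.5% in this assay, and its step from the first compound is a number 1.8 percentage points lower from compound 1 to compound 3 (within the scatter). All three numbers lie within the scatter of one another, so no ordering among them is claimed.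

Compound 4 `Cc1c(OCCCCOc2ccc(C(=O)O)c(Cl)c2)ccc(C(=O)CC2CCCC2)c1C` is not yet measured. It differs from compound 3 by 4-carboxy-3-chlorophenyl in place of 3-carboxyphenyl on an oxygen on a saturated carbon, which is the same change as between compound 1 and compound 2, at the same place; the two cores differ by cyclopentyl in place of isopropyl on a saturated chain carbon bound to a carbonyl carbon. Within the data shown here, the single measured instance of this change was small and within the scatter.

For compound 4 a step of a number 5 percentage points lower from compound 3 to compound 4 (within the scatter) in this assay is expected, resting on a number 6.3 percentage points lower from compound 1 to compound 2 (within the scatter) and on compound 3 standing at 16.5%. Compound 4 is accordingly estimated at 11.5% in this assay, with a range from 5% to 18%.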

Compound 4, largest response reached (reported as percent of maximum), in percent of the reference or control that the assay uses: 35.5%
The estimate for compound 4 lay 24 percentage points below the measured number; the measured number lies above the stated range.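

Carrying 4-carboxy-3-chlorophenyl in place of 3-carboxyphenyl from one core to the other does not preserve the step in this assay, where the core of compound 3 gives a number 19 percentage points higher from compound 3 to compound 4 (beyond the scatter) and the step differs from the one on the core of compound 1: the same change on two cores in this assay, a number 6.3 percentage points lower (within the scatter) from compound 1 to compound 2 and a number 19 percentage points higher (beyond the scatter) from compound 3 to compound 4, 25.3 percentage points apart, beyond the scatter of two such steps
Read the other way, cyclopentyl in place of isopropyl gives a number 23.5 percentage points higher from compound 2 to compound 4 (beyond the scatter) with 4-carboxy-3-chlorophenyl present, so the two changes do not add up in these four compounds: the same change on two cores in this assay, a number 1.8 percentage points lower (within the scatter) from compound 1 to compound 3 and a number 23.5 percentage points higher (beyond the scatter) from compound 2 to compound 4, 25.3 percentage points apart, beyond the scatter of two such steps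
The effect of each change therefore depends on the other here, but this rests on a single set of four compounds and does not show how the change would behave on any further core, nor what underlies the dependence.

Left open is whether bromine or a methyl group in place of the chlorine, or cyclohexyl in place of cyclopentyl, would behave like compound 4 or like compound 3. Also open, from the compounds shown here alone, is whether the step to compound 4 would survive a longer chain in the linker.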